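A few compounds are considered here, and "the series" means these few. Any claim that something is new, unique, unknown or untested is made for them only; others in the source may bear on it.

Compound 1 `C=CCNC(=O)n1c(-c2ccc(OC)cc2)cc(=O)c2c(OC)cc(OC)cc21`: 12000 nM
Compound 2 `COc1ccc(-c2c(Br)c(=O)c3c(OC)cc(OC)cc3n2S(=O)(=O)c2ccc(OC)cc2)cc1`: 2580 nM

Of the two compounds measured in a functional assay on KOPN-8 cells (Homo sapiens) for antiproliferative activity, with a stated time of 72 h (a lower number here means that less compound is needed, a higher number that more compound is needed for the effect), compound 1 gives the higher number, 12000 nM, while compound 2 gives 2580 nM, a gap that lies beyond the scatter. Compound 3 `COc1ccc(-c2cc(=O)c3c(OC)cc(OC)cc3n2S(=O)(=O)c2ccc(F)cc2)cc1` has not yet been measured. It differs from compound 1 in one place: (4-fluorophenyl)sulfonyl in place of allylcarbamoyl on an aromatic nitrogen. For the measured compounds named here, compound 2 also carries a sulfonyl group on the aromatic nitrogen of the shared core, but it differs from compound 3 in further places, so its value shows only that a sulfonyl group on that nitrogen is compatible with a lower number in this assay . The change from compound 1 is therefore expected to lower the number, by a moderate step: a 3.0-fold lower number from compound 1 to compound 3 (0.48 log units; beyond the scatter). On this basis compound 3 is estimated to give 4000 nM, within a range from 1500 nM to 12000 nM.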

Compound 3, half-maximal effective concentration: > 65500 nM
Compound 3: a limit, no number; the forecaster's own chance of this, stated with the estimate: 5%; middle value at least 16-fold (1.21 log units) away from the limit.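

In this assay, compound 3 gives > 65500 nM, which is a limit of the assay and not a number. The exchange of allylcarbamoyl for (4-fluorophenyl)sulfonyl on the aromatic nitrogen gives an at least 5.4-fold higher number from compound 1 to compound 3 (0.73 log units; beyond the scatter), the first step read at this position, and it shows that the number here depends strongly on the group on that nitrogen and can rise as well as fall. Only the lower end of this step is known, because compound 3 stands at a limit: the limit of > 65500 nM in this assay, at which 1 of the 3 values shown sits.

The compounds shown leave open how a methyl group, an acetyl group or a longer chain ending in an amine on this nitrogen would compare with allylcarbamoyl. They also leave open which of the differences in compound 2, the bromine or the methoxy on its sulfonyl aryl ring, goes with its lower number.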